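The compounds below may be only part of what the source reports. "The series", "measured", "known", "first", "only" and "open" are said of these compounds alone.

Working notes on the series. The shared core is carried by compound 1 `CC(C)(C)c1csc(N)c1C(=O)c1ccc(Cl)cc1`, compound 2 `CC(C)(C)Cc1c(-c2c(F)cccc2F)sc(N)c1C(=O)c1ccc(Cl)cc1` and compound 3 `CC(C)(C)Cc1c(-c2ccccc2)sc(N)c1C(=O)c1ccc(Cl)cc1Cl`. In an assay on CHO cells for displacement of a labelled ligand from adenosine receptor A1 (Homo sapiens), read by scintillation counting, tested at 10 uM (a higher number here means more inhibition at the concentration tested (going by the name of the read-out), a lower number less inhibition), compound 1 gives 1%. In this assay compound 2 gives 1%, and compound 3 gives 1%. Compound 2 thus stands level with compound 1 and compound 3 at the digits shown: against compound 1 there is no change within the scatter, and against compound 3 there is likewise none. Going by the values given here, no two of these three compounds differ in one place only, so no single step between measured compounds can be drawn; what the numbers show is that three different substitution patterns on the core all sit at the floor of the read-out.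

Compound 4 `CC(C)(C)Cc1c(-c2ccsc2)sc(N)c1C(=O)c1ccc(Cl)cc1` has not yet been measured. It differs from compound 2 as follows: thiophen-3-yl in place of 2,6-difluorophenyl on an aromatic carbon. Among the compounds with values here, nothing among the measured compounds suggests that a change at this position moves the read-out, because compound 2 gives 1% and compound 3 gives 1% with different groups there. The step expected is a number 1 percentage points higher from compound 2 to compound 4 (within the scatter), which is none beyond the scatter. Compound 4 is therefore expected to give 2% in this assay, within a range from 0% to 12%.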

Compound 4, a percentage reported as inhibition, at one concentration (the size of the read-out at that concentration, not a potency): 2%
The estimate for compound 4 equals the measured number at the digits printed, and the stated range covers the measured number.
By their numbers in this assay, from the lowest: compounds 1, 2, 3 and 4 (each within the scatter of the next).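

In this assay, going by these compounds alone, thiophen-3-yl in place of 2,6-difluorophenyl on the aromatic carbon next to the ring sulfur gives a number 1 percentage points higher from compound 2 to compound 4 (within the scatter) and this is the first step that can be read at a single place. It shows directly what compounds 2 and 3 could only hint at, since they differ in more than one place: a five-membered aromatic ring with one sulfur and a six-membered aromatic ring of carbon only, bearing two fluorines, can replace each other here with no change beyond the scatter, but both compounds sit at the floor of the read-out, so the step says little about how far this position could matter in a compound with clear displacement. No measurement among the data shown offers an explanation for this result.

As far as these compounds go, whether a group of another kind at this carbon, such as a carboxylic acid, an aminomethyl group or a morpholine ring, would lift the read-out clear of the floor stays open. Also open, from the compounds shown here alone, is whether replacing the neopentyl group or the (4-chlorophenyl)carbonyl group, each taken alone, would do so.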